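Swapping the Sulfonamide Heteroaryl in a Coumarin Series

A few compounds are considered here, and "the series" means these few. Any claim that something is new, unique, unknown or untested is made for them only; others in the source may bear on it.

Measured so far:
- compound 1, `O=c1oc2ccccc2c(Cl)c1/C=N/c1ccc(S(=O)(=O)Nc2nccs2)cc1`: 300 nM
- compound 2, `Cc1cc(C)nc(NS(=O)(=O)c2ccc(/N=C/c3c(Cl)c4ccccc4oc3=O)cc2)n1`: 170 nM

Compound 1 was tested in a functional assay on B16-F10 cells (Mus musculus) for cytotoxicity, read by CCK-8 assay, with a stated time of 48 h (a higher number here means a weaker inhibitor, a lower number a stronger inhibitor), and gives 300 nM. Among the two numbers available it is the highest, but its only neighbour is compound 2, which gives 170 nM, and the two values lie within the scatter of each other, so nothing can be said about an order between them.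

The compound now in question is compound 3, `Cc1ccnc(NS(=O)(=O)c2ccc(/N=C/c3c(Cl)c4ccccc4oc3=O)cc2)n1`. It differs from compound 1 in one place: 4-methylpyrimidin-2-yl in place of 1,3-thiazol-2-yl on a sulfonamide nitrogen.

Among the compounds with values here, only one measured step bears on this change: a 1.8-fold lower number from compound 1 to compound 2 (0.25 log units; within the scatter). That step also replaced the 1,3-thiazol-2-yl group on the sulfonamide nitrogen with a pyrimidinyl ring, there carrying two methyl groups instead of one, and it stayed within the scatter. For compound 3 a similar outcome is therefore expected, a step of a 1.4-fold lower number from compound 1 to compound 3 (0.13 log units; within the scatter), not beyond the scatter in either direction.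

On that basis compound 3 is estimated to give 220 nM, with a range from 110 nM to 450 nM.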

Compound 3, half-maximal inhibitory concentration: 230 nM
Compound 3: the middle estimate sits 1.0-fold (0.02 log units) below what was measured; measured number inside the range.
By their numbers in this assay, from the lowest: compounds 2, 3 and 1 (each within the scatter of the next).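

In this assay, putting 4-methylpyrimidin-2-yl in place of 1,3-thiazol-2-yl on the sulfonamide nitrogen gives a 1.3-fold lower number from compound 1 to compound 3 (0.12 log units; within the scatter) and so adds a second pyrimidinyl example to the earlier one, again with no readable difference from the 1,3-thiazol-2-yl compound. The new information concerns the methyl groups on that ring: hydrogen in place of methyl on an aromatic carbon gives a 1.4-fold higher number from compound 2 to compound 3 (0.13 log units; within the scatter) and shows that, in this pair, removing one methyl group leaves no readable difference either. Nothing available gives a reason for this flat picture across the three compounds.

All three groups on the sulfonamide nitrogen are aromatic rings containing nitrogen, so the compounds shown leave open what a plain phenyl ring, a simple ethyl chain or a hydrogen would do there. Also open, on these data alone, is whether a methoxy group, a carboxylic acid or a longer chain in place of methyl on the pyrimidinyl ring would produce a step beyond the scatter.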